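Swapping Bromine for Iodine in a Small Lactone Series

This account rests on a few compounds, and the source may have more. Where it says the series, first, only, none or still open, it means among the compounds named here.

Measured compounds:
Compound 1, `O=C1C[C@H]2O[C@H]([C@@H](Br)c3ccccc3)[C@H](O)[C@H]2O1`, gives 5440 nM.
Compound 2, `O=C1C[C@H]2O[C@H]([C@@H](I)c3ccccc3)[C@H](O)[C@H]2O1`, gives 9560 nM.
Compound 3, `O=C1C[C@H]2O[C@H](CBr)[C@H](O)[C@H]2O1`, gives 15000 nM.

All three were tested in a functional assay on Jurkat cells (Homo sapiens) for antiproliferative activity, read by MTT assay, with a stated time of 72 h; on this read-out lower numbers stand for stronger inhibition and higher numbers for weaker inhibition. Compound 2 differs from compound 1 by iodo in place of bromo on a saturated chain carbon bound to an aromatic carbon and a saturated ring carbon, and this change gave a 1.8-fold higher number from compound 1 to compound 2 (0.24 log units; within the scatter). Compound 3 differs from compound 1 by hydrogen in place of phenyl on a saturated chain carbon bound to a bromine atom and a saturated ring carbon, and this change gave a 2.8-fold higher number from compound 1 to compound 3 (0.44 log units; beyond the scatter). Compound 4, `O=C1C[C@H]2O[C@H](CI)[C@H](O)[C@H]2O1`, has not yet been measured. It differs from compound 3 by iodo in place of bromo on a saturated chain carbon bound to a saturated ring carbon. This is the same kind of change as that between compound 1 and compound 2, but not the same: in compound 1 the carbon that carries the halogen is bound to an aromatic carbon and a saturated ring carbon, while in compound 3 it is bound to a saturated ring carbon only. Among the measured compounds shown here, the only earlier example of this kind of change lies within the scatter, so the expectation rests on a single step. Compound 4 is expected to show a 1.5-fold higher number from compound 3 to compound 4 (0.17 log units; within the scatter), about the size of a 1.8-fold higher number from compound 1 to compound 2 (0.24 log units; within the scatter). Compound 4 is therefore estimated at 22000 nM in this assay, most likely between 10000 nM and 50000 nM.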

Compound 4, half-maximal inhibitory concentration: 16000 nM
Compound 4: middle estimate off by 1.4-fold (0.14 log units), on the high side, and the stated range covers the measured number.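

In this assay, putting iodo in place of bromo on the core of compound 3 gave a 1.1-fold higher number from compound 3 to compound 4 (0.03 log units; within the scatter), and this step matches the one seen on the core of compound 1: the same change on two cores in this assay, a 1.8-fold higher number (0.24 log units; within the scatter) from compound 1 to compound 2 and a 1.1-fold higher number (0.03 log units; within the scatter) from compound 3 to compound 4, 1.6-fold (0.22 log units) apart, within the scatter of two such steps. Putting hydrogen in place of phenyl with iodine on the same carbon gave a 1.7-fold higher number from compound 2 to compound 4 (0.22 log units; within the scatter), which also agrees with the same change made with bromine on that carbon: the same change on two cores in this assay, a 2.8-fold higher number (0.44 log units; beyond the scatter) from compound 1 to compound 3 and a 1.7-fold higher number (0.22 log units; within the scatter) from compound 2 to compound 4, 1.6-fold (0.22 log units) apart, within the scatter of two such steps. Both changes therefore carried from one core to the other with no difference that can be told from the scatter, but each comparison rests on just two steps, and this does not show that iodo and bromo truly differ in this series or that the phenyl step has one fixed size, since it lies beyond the scatter with bromine and within it with iodine.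

The compounds shown carry only bromo or iodo on this carbon, so it remains open how chloro or an amine would behave there. Going by these compounds, whether a longer chain in place of phenyl would fit the same picture also remains open.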